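Does a smaller fluorinated ring keep the long half-life?

The source may hold more compounds than are shown below. What is called first, only, known or untested is meant among the compounds shown, and "the series" means these compounds.

Measured so far in an ADME assay on microsomes from liver (Homo sapiens) for metabolic stability, read by LC-MS, using NADPH, with a stated time of 10 min, tested at 10 uM; a higher number here means that the compound lasts longer, a lower number that the compound disappears faster:
- compound 1 `Nc1ncnc2c1c(Oc1cc(C(F)(F)F)ccn1)nn2C1CCCC1`: 0.333 h
- compound 2 `Nc1ncnc2c1c(Oc1cc(O)ccn1)nn2C1CCC(F)(F)CC1`: > 2.41 h
- compound 3 `Nc1ncnc2c1c(Oc1cc(Cl)ccn1)nn2C1CCC1`: 0.333 h

Compound 2 stands at the limit of > 2.41 h in this assay, at which 1 of the 3 values shown sits. That figure is a limit of the assay and not a number.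

The next molecule is compound 4 `Nc1ncnc2c1c(Oc1cc(O)ccn1)nn2[C@H]1C[C@H](F)C1`, which keeps the shared core and the (4-hydroxypyridin-2-yl)oxy group of compound 2. It carries 3-fluorocyclobutyl in place of 4,4-difluorocyclohexyl on an aromatic nitrogen.

For the measured compounds named here, no two measured compounds differ in just one place, so no measured step shows how large this change might be. The starting expectation in this assay is therefore little or no change beyond the scatter, with any shift more likely to be towards a shorter half-life. Compound 3 also has a four-membered ring at that nitrogen and gives 0.333 h, but it lacks the hydroxy group of compound 2, so it is only a weak warning.

The expected size of the change is an at least 1.0-fold lower number from compound 2 to compound 4 (0.03 log units; that floor lies within the scatter). For compound 4 the estimated half-life is 2.2 h, with an expected range of 0.8 h to 3.5 h.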

Compound 4, half-life: 1.03 h
The estimate for compound 4 lay 2.1-fold (0.33 log units) above the measured number; measured number inside the range.
By their numbers in this assay, from the lowest: compounds 1 and 3 (each within the scatter of the next); then compound 4. At a limit, above all of these: compound 2.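

For the compounds shown here, this is the first step in this assay between two compounds that differ in only one place, so it gives the first direct reading of the group on the aromatic nitrogen while the (4-hydroxypyridin-2-yl)oxy group stays fixed. Putting 3-fluorocyclobutyl in place of 4,4-difluorocyclohexyl gives an at least 2.3-fold lower number from compound 2 to compound 4 (0.36 log units; beyond the scatter) and shows that the half-life responds to this position by more than the usual scatter. The change alters ring size and the number of fluorine atoms together, and compound 2 stands at a limit of the assay and not at a number: the limit of > 2.41 h in this assay, at which 1 of the 4 values shown sits.

Still open, as far as these compounds go, is which of the two differences matters, since a plain cyclohexyl or a 3,3-difluorocyclobutyl group would be needed to pull ring size and fluorine count apart. Also open is how the other stereoisomer of 3-fluorocyclobutyl would behave, as the compounds shown hold only one arrangement of its two defined stereocentres.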